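Methoxy on the shared core: from compound 2 to compound 4

The source may hold more compounds than are shown below. What is called first, only, known or untested is meant among the compounds shown, and "the series" means these compounds.

Measured so far:
Compound 1 `O=S(=O)(c1cnc2ccccc2c1)n1cc(C2=CCNCC2)c2ccccc21` in an assay on HEK293 cells for displacement of a labelled ligand from 5-hydroxytryptamine receptor 6 (Homo sapiens), read by scintillation counting (a higher number here means a weaker inhibitor, a lower number a stronger inhibitor), gives 13 nM.
Compound 2 `O=S(=O)(c1ccc2cccnc2c1)n1cc(C2=CCNCC2)c2ccccc21` in this assay gives 7 nM.
Compound 3 `O=S(=O)(c1cncc2ccccc12)n1cc(C2=CCNCC2)c2ccccc21` in this assay gives 5 nM.

Three compounds share one core and differ only in the bicyclic nitrogen-containing aromatic group attached to the sulfonyl. Compound 2 stands second highest of the three numbers. Its nearest neighbour is compound 3, whose number is lower, and its furthest is compound 1, whose number is higher; both gaps lie within the scatter of repeated measurements, so the three compounds are not told apart by these data, and none can be called the strongest or the weakest.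

Compound 4 `COc1ccc2c(c1)c(C1=CCNCC1)cn2S(=O)(=O)c1ccc2cccnc2c1` keeps the sulfonyl group of compound 2 and changes the shared core: methoxy in place of hydrogen on an aromatic carbon. For the measured compounds named here, no pair of measured compounds that differ in this way exists, so the size of this step rests on expectation alone. The account expects the step of a 1.4-fold lower number from compound 2 to compound 4 (0.15 log units; within the scatter) to fall within the scatter, with at most a slight move toward a lower number.

Compound 4 is therefore estimated at 5 nM in this assay, with a range from 1.5 nM to 20 nM.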

Compound 4, inhibition constant: 2 nM
Beside the measured number, compound 4's estimate is 2.5-fold (0.40 log units) above it, within the range that was stated.
By their numbers in this assay, from the lowest: compound 4; then compounds 3, 2 and 1 (each within the scatter of the next, the first and the last beyond it).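

In this assay, methoxy in place of hydrogen on an aromatic carbon of the shared core gives a 3.5-fold lower number from compound 2 to compound 4 (0.54 log units; beyond the scatter), a modest step but one that lies beyond the scatter. The earlier compounds shown here all carry hydrogen at this carbon and vary only in the group on the sulfonyl, so they said nothing about this position; the new pair shows that the carbon, meta to a fused ring and para to a fused ring, takes methoxy with a lower number rather than a higher one. Nothing in the data shown accounts for the size or direction of this step.

For the compounds shown here, the change is seen only with the sulfonyl group of compound 2, so whether methoxy brings a similar step to compound 1 or compound 3 remains open. Also open, as far as these compounds go, is whether the step belongs to methoxy itself or would also appear with ethoxy, a hydroxyl group or a chlorine atom on the same carbon, and what methoxy would do on the other aromatic carbons of the core.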